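Aryl tetrazole series: chlorophenyl replacing pyridin-2-yl

The compounds below may be only part of what the source reports. "The series", "measured", "known", "first", "only" and "open" are said of these compounds alone.

Compound 3 `Cc1cc(NC(=O)Cn2nnc(-c3ccccn3)n2)n(C2CCCCC2)n1` gives 81% in an assay on HEK293 cells for activation of Kir3.1/Kir3.2 (Homo sapiens), read by thallium flux (a lower number here means a smaller maximal response, a higher number a larger maximal response), and stands lowest of the three measured compounds. Compound 1 `Cc1cc(NC(=O)Cn2nnc(-c3ccccc3)n2)n(C2CCCCC2)n1` gives 92% and compound 2 `Cc1cc(NC(=O)Cn2nnc(-c3cccnc3)n2)n(C2CCCCC2)n1` gives 96%; the two differ by a number 4 percentage points higher from compound 1 to compound 2 (within the scatter). Compound 4 `Cc1cc(NC(=O)Cn2nnc(-c3cccc(Cl)c3)n2)n(C2CCCCC2)n1` differs from compound 3 by 3-chlorophenyl in place of pyridin-2-yl on an aromatic carbon. The bearing steps are a number 11 percentage points lower from compound 1 to compound 3 (beyond the scatter) and a number 15 percentage points lower from compound 2 to compound 3 (beyond the scatter), both modest, both pointing to a smaller maximal response when pyridin-2-yl enters; removing it again should therefore recover that loss. Going by these compounds, how a chlorine on the phenyl ring acts is untested, so the expectation rests on the phenyl level of compound 1. Compound 4 is expected to show a number 9 percentage points higher from compound 3 to compound 4 (within the scatter), giving an estimated 90% within 78% to 100%.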

Compound 4, largest response reached (Emax), in percent of the reference or control that the assay uses: 89%
Compound 4: middle estimate off by 1 percentage points, on the high side; measured number inside the range.
By their numbers in this assay, from the lowest: compounds 3, 4, 1 and 2 (each within the scatter of the next, the first and the last beyond it).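

At this aromatic carbon of the five-membered aromatic ring with 4 nitrogen, chlorine on the phenyl ring leaves the maximal response in this assay unresolved from the unsubstituted phenyl, with a number 3 percentage points lower from compound 1 to compound 4 (within the scatter). The 3-chlorophenyl group also sits within the scatter of both pyridine groups, with a number 8 percentage points higher from compound 3 to compound 4 (within the scatter) and a number 7 percentage points lower from compound 2 to compound 4 (within the scatter), so it does not reproduce the separation seen between those two. Nothing available accounts for these levels.

Going by these compounds, whether an amine, a methoxy or a nitrile in place of the chlorine would hold this response stays open.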